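Moving the Formyl Group: Compound 2 to Compound 3

The compounds below may be only part of what the source reports. "The series", "measured", "known", "first", "only" and "open" are said of these compounds alone.

Measured in a functional assay on COLO 205 cells (Homo sapiens) for inhibition, read by MTT assay, with a stated time of 48 h; on this read-out lower numbers stand for stronger inhibition and higher numbers for weaker inhibition:
Compound 1 `COc1cc(C(=O)/C=C/c2ccc(O)c(O)c2)cc(OC)c1OC`: 19800 nM
Compound 2 `COc1cc(C(=O)/C=C/c2ccccc2C=O)cc(OC)c1OC`: 88000 nM

Within the data shown here, compound 2 holds the higher of the two numbers, and the only measured step is a 4.4-fold higher number from compound 1 to compound 2 (0.65 log units; beyond the scatter). That step lies beyond the scatter and is modest. It exchanged 3,4-dihydroxyphenyl for 2-formylphenyl on a double-bonded chain carbon bound to a double-bonded chain carbon.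

Compound 3 `COc1cc(C(=O)/C=C/c2cccc(C=O)c2)cc(OC)c1OC` changes the same place, with the same atoms joined differently: 3-formylphenyl in place of 2-formylphenyl on a double-bonded chain carbon bound to a double-bonded chain carbon. Among the measured compounds shown here, the earlier step is the only guide, and no measured pair shows what moving the formyl group does. Since 3-formylphenyl replaces 2-formylphenyl with equal counts, a smaller change than the earlier one is expected in this assay, with no clear direction and nothing beyond the scatter. The expected change is a 1.4-fold lower number from compound 2 to compound 3 (0.13 log units; within the scatter). Compound 3 is estimated at 65000 nM, with an expected range of 25000 nM to 140000 nM.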

Compound 3, half-maximal inhibitory concentration: 22500 nM
Estimate against measurement, compound 3: 2.9-fold (0.46 log units) above, and the stated range ends above it.
By their numbers in this assay, from the lowest: compounds 1 and 3 (each within the scatter of the next); then compound 2.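

In this assay the position of the formyl group on the ring matters at this place on a double-bonded chain carbon, since 3-formylphenyl in place of 2-formylphenyl, with the same atoms joined differently, gives a 3.9-fold lower number from compound 2 to compound 3 (0.59 log units; beyond the scatter) and this lies beyond the scatter. Exchanging 3,4-dihydroxyphenyl for 3-formylphenyl gives a 1.1-fold higher number from compound 1 to compound 3 (0.06 log units; within the scatter) and so leaves the two compounds level, which ties the earlier rise in the number to 2-formylphenyl and not to every formyl-bearing ring among the compounds shown. Nothing at hand explains why the position of the formyl group counts here.

On these data alone, whether a carboxylic acid or an amine in place of the formyl group would hold the number of compound 3 remains open. So does whether the same move of the formyl group would act alike on another core.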